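The source may report more compounds than this note shows. Statements on the series, on what has been measured and on what is new or still open speak of the compounds shown alone.

Measured in a functional assay on HeLa cells (Homo sapiens) for inhibition, read by CCK-8 assay, with a stated time of 48 h; on this read-out higher numbers stand for weaker inhibition and lower numbers for stronger inhibition:
- compound 1 `COc1ccc(C2=NN(C3=NC(c4ccccc4)CS3)C(c3cccc4ccccc34)C2)cc1` gives 3310 nM
- compound 2 `COc1ccc(C2=NN(C3=NC(c4ccccc4)CS3)C(c3ccc4ccccc4c3)C2)cc1` gives 1860 nM
- compound 3 `O=C1CSC(N2N=C(c3ccc(F)cc3)CC2c2ccc3ccccc3c2)=N1` gives 9170 nM

Among these three, compound 2 at 1860 nM holds the lowest number, but it lies within the scatter of compound 1 at 3310 nM. The gap is clear only against compound 3 at 9170 nM, which differs from compound 2 in more than one place.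

The next compound is compound 4 `Clc1ccc(C2=NN(C3=NC(c4ccccc4)CS3)C(c3ccc4ccccc4c3)C2)cc1`, which keeps the core and the naphthalen-2-yl group of compound 2. It carries chloro in place of methoxy on an aromatic carbon, para to a large group, so that 4-methoxyphenyl becomes 4-chlorophenyl (chloro in place of methoxy on an aromatic carbon).

For the measured compounds named here, the only measured single-place step is a 1.8-fold lower number from compound 1 to compound 2 (0.25 log units; within the scatter). It concerns the naphthalenyl attachment on a saturated ring carbon, not this aromatic position, so it offers no direct guide. Going by the values given here, no measured pair shows what this exchange does. In this assay no step beyond the scatter is therefore expected, in either direction, and the range is kept wide. The estimated change is a 1.0-fold lower number from compound 2 to compound 4 (0.01 log units; within the scatter). For compound 4 the expected value is 1800 nM, with an estimated range of 700 nM to 4500 nM.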

Compound 4, half-maximal inhibitory concentration: 7560 nM
Estimate against measurement, compound 4: 4.2-fold (0.62 log units) below; measured number outside the range, above it.
By their numbers in this assay, from the lowest: compounds 2 and 1 (each within the scatter of the next); then compounds 4 and 3 (each within the scatter of the next).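

In this assay, replacing 4-methoxyphenyl with 4-chlorophenyl gives a 4.1-fold higher number from compound 2 to compound 4 (0.61 log units; beyond the scatter), the only single-place step shown here that lies beyond the scatter. This shows that the aromatic position, para to a large group, responds to this exchange even when the naphthalen-2-yl group and the shared core stay the same. Between these two groups, methoxy goes with the lower number and thus the stronger inhibition, although this rests on one pair and the step is modest. No measurement shown here bears on the reason for this step.

The compounds shown leave open whether a hydroxyl or a dimethylamino group at this place would give a number closer to that of methoxy or to that of chloro. They also leave open whether the same exchange of methoxy for chloro would give a step of similar size if the naphthalen-1-yl group of compound 1 stood in place of the naphthalen-2-yl group.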